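From 4-Chlorophenyl to 4-Methylpiperazin-1-yl on a Shared Core

This account rests on a few compounds, and the source may have more. Where it says the series, first, only, none or still open, it means among the compounds named here.

Compound 1 `CC(C)(C)n1cc2c(n1)C(=O)CC1(CCN(C(=O)c3cc(-c4ccc(Cl)cc4)nc4ccccc34)CC1)O2` carries a 4-chlorophenyl group on the shared core. In a functional assay on A549 cells (Homo sapiens) for inhibition, read by MTT assay, with a stated time of 72 h (a lower number here means a stronger inhibitor, a higher number a weaker inhibitor), compound 1 gives 2330 nM, the highest of the three numbers measured here. Compound 2 `CN(C)c1ccc(-c2cc(C(=O)N3CCC4(CC3)CC(=O)c3nn(C(C)(C)C)cc3O4)c3ccccc3n2)cc1`, which bears a 4-(dimethylamino)phenyl group in the same place, gives 1150 nM in this assay, and compound 3 `CC(C)(C)n1cc2c(n1)C(=O)CC1(CCN(C(=O)c3cc(-c4ccncc4)nc4ccccc34)CC1)O2`, with a pyridin-4-yl group there, gives 550 nM. The step of a 2.0-fold lower number from compound 1 to compound 2 (0.31 log units; beyond the scatter) and the step of a 4.2-fold lower number from compound 1 to compound 3 (0.63 log units; beyond the scatter) both lower the number, and the step of a 2.1-fold lower number from compound 2 to compound 3 (0.32 log units; beyond the scatter) lowers it further.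

Compound 4 `CN1CCN(c2cc(C(=O)N3CCC4(CC3)CC(=O)c3nn(C(C)(C)C)cc3O4)c3ccccc3n2)CC1` differs from compound 1 in one place: 4-methylpiperazin-1-yl in place of 4-chlorophenyl on an aromatic carbon. Both measured steps from compound 1 bear on this change: each replaces the 4-chlorophenyl group of compound 1, and each gave a modest drop in the number. The entering group here is not an aromatic ring, so the change is larger in kind than either measured step, and the expectation rests on them only loosely. A modest drop in this assay is expected, roughly a 2.3-fold lower number from compound 1 to compound 4 (0.37 log units; beyond the scatter). Compound 4 is therefore estimated to give 1000 nM in this assay, within a range from 250 nM to 4000 nM.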

Compound 4, half-maximal inhibitory concentration: > 10000 nM
Compound 4 gave a limit, no number; the forecaster's own chance of this, stated with the estimate: 10%; middle value at least 10-fold (1.00 log units) away from the limit.
By their numbers in this assay, from the lowest: compound 3; then compound 2; then compound 1. At a limit, above all of these: compound 4.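

In this assay, compound 4 gives a limit and not a number: the limit of > 10000 nM in this assay, at which 1 of the 4 values shown sits.

Read against that limit, the change runs the other way from the earlier replacements of 4-chlorophenyl, with an at least 4.2-fold higher number from compound 1 to compound 4 (0.63 log units; beyond the scatter), alongside an at least 8.6-fold higher number from compound 2 to compound 4 (0.93 log units; beyond the scatter) and an at least 18-fold higher number from compound 3 to compound 4 (1.25 log units; beyond the scatter). Among these four compounds, then, the group on this aromatic carbon next to the ring nitrogen is not interchangeable: the three six-membered aromatic rings all give numbers, while 4-methylpiperazin-1-yl, a non-aromatic ring with the same count of heavy atoms as 4-chlorophenyl, reaches the limit.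

The compounds shown leave open how far above the limit compound 4 lies, and whether the change follows from losing the aromatic ring or from something particular to 4-methylpiperazin-1-yl. A morpholin-4-yl or piperidin-1-yl group in this place, or a 4-(4-methylpiperazin-1-yl)phenyl group that keeps the aromatic ring and carries the piperazine further out, would help to separate these readings.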